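Trimethoxyphenyl analogue: expectation for compound 4

The source may report more compounds than this note shows. Statements on the series, on what has been measured and on what is new or still open speak of the compounds shown alone.

Three compounds of the shared core have been run in a functional assay on HCC 2998 cells (Homo sapiens) for antiproliferative activity, with a stated time of 48 h; a higher number here means a weaker inhibitor of growth, a lower number a stronger inhibitor of growth. Compound 1 `Cc1cc(O)c(C2=NN(c3ccc(S(N)(=O)=O)cc3)C(c3ccccc3Cl)C2)cc1Cl` gives 3910 nM; compound 2 `Cc1cc(O)c(C2=NN(c3ccc(S(N)(=O)=O)cc3)C(/C=C/c3ccccc3)C2)cc1Cl` gives 30300 nM; compound 3 `COc1ccc(C2CC(c3cc(Cl)c(C)cc3O)=NN2c2ccc(S(N)(=O)=O)cc2)cc1OC` gives 7250 nM. Compound 3 thus stands second highest of the three numbers, close to compound 1 and clearly apart from compound 2. Compound 4 `COc1ccc(C2CC(c3cc(Cl)c(C)cc3O)=NN2c2ccc(S(N)(=O)=O)cc2)c(OC)c1OC` differs from compound 3 by methoxy in place of hydrogen on an aromatic carbon. Among the measured compounds shown here, no measured step adds a group to the pendant aryl; the steps that exchange that aryl entirely, a 1.9-fold higher number from compound 1 to compound 3 (0.27 log units; within the scatter) and a 4.2-fold lower number from compound 2 to compound 3 (0.62 log units; beyond the scatter), run from within the scatter to modest, so a smaller change is expected to stay within the scatter in this assay, the expected step being a 1.1-fold higher number from compound 3 to compound 4 (0.04 log units; within the scatter). Compound 4 is estimated at 8000 nM, ranging from 3500 nM to 18000 nM.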

Compound 4, concentration for total growth inhibition: 3750 nM
Beside the measured number, compound 4's estimate is 2.1-fold (0.33 log units) above it, within the range that was stated.
By their numbers in this assay, from the lowest: compounds 4, 1 and 3 (each within the scatter of the next); then compound 2.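

In this assay, methoxy on the aromatic carbon ortho to a large group and ortho to a methoxy group leaves the number within the scatter (a 1.9-fold lower number from compound 3 to compound 4 (0.29 log units; within the scatter)), so this position accepts that group without a readable change. The 2,3,4-trimethoxyphenyl and 2-chlorophenyl groups also read alike (a 1.0-fold lower number from compound 1 to compound 4 (0.02 log units; within the scatter)), while the gap to 2-phenylethenyl is beyond the scatter (an 8.1-fold lower number from compound 2 to compound 4 (0.91 log units; beyond the scatter)). No available evidence bears on the reason for this result.

As far as these compounds go, whether this position also accepts an amine, a carboxylic acid or a longer chain such as butoxy remains open.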